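A few compounds are considered here, and "the series" means these few. Any claim that something is new, unique, unknown or untested is made for them only; others in the source may bear on it.

Compound 1 `CC(C)N/C(=N\c1nccn1C(C)(C)C)Nc1ccc(Cl)c(Cl)c1`: 0.8 h
Compound 2 `CC(C)(C)n1ccnc1/N=C(\N)Nc1ccc(Cl)c(Cl)c1`: > 1 h (a limit)
Compound 3 `N/C(=N\c1nccn1Cc1ccccc1)Nc1ccc(Cl)c(Cl)c1`: > 1 h (a limit)

Going by the values given here, in an in vitro ADME assay on microsomes from liver (Homo sapiens) for metabolic stability, read by LC-MS, tested at 1 uM (a higher number here means that the compound lasts longer, a lower number that the compound disappears faster), compound 1 gives 0.8 h, and this is the only plain number among the three. Compound 2 and compound 3 both sit at the limit of > 1 h in this assay, at which 2 of the 3 values shown sit, which is a limit of the measurement and not a number.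

Compound 4 `CC(C)N/C(=N\c1ncc[nH]1)Nc1ccc(Cl)c(Cl)c1` differs from compound 1 by hydrogen in place of tert-butyl on an aromatic nitrogen. Two measured steps offer some guidance, though neither is the same change. The step of an at least 1.2-fold higher number from compound 1 to compound 2 (0.09 log units; that floor lies within the scatter) alters a different nitrogen, and its size is not readable beyond the scatter. The step that the two limits leave unreadable from compound 2 to compound 3 touches the same aromatic nitrogen but, with both ends at a limit, cannot be sized at all.

With no readable step for this change, compound 4 is expected to stay close to compound 1 in this assay. The expected step is a 1.3-fold higher number from compound 1 to compound 4 (0.10 log units; within the scatter). Compound 4 is estimated at 1 h, with a range from 0.5 h to 2 h, and a fair chance that only a limit is reported.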

Compound 4, half-life: > 1 h
Compound 4 was reported as a limit; the forecaster's own chance of this, stated with the estimate: 40%; the middle value lies on the limit itself.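

In this assay, going by these compounds alone, this is the first step at the aromatic nitrogen that can be read at all, since the earlier change at that nitrogen ran between two limits and cannot be read. Replacing the tert-butyl with a hydrogen on that nitrogen gives an at least 1.2-fold higher number from compound 1 to compound 4 (0.09 log units; that floor lies within the scatter). With the isopropyl on the amine nitrogen kept, the tert-butyl is therefore not needed for the half-life to stay level with that of compound 1 or go higher, although the value of compound 4 is a limit and not a number.

Going by these compounds, how far past this limit compound 4 lies remains unknown, and so does any order among the compounds that share it: the limit of > 1 h in this assay, at which 3 of the 4 values shown sit. Also open, on these data alone, is what a methyl group or a longer chain on this aromatic nitrogen would do to the half-life.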